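The compounds below may be only part of what the source reports. "The series", "measured", "known", "first", "only" and "open" are said of these compounds alone.

Measured compounds:
compound 1 `CN1CCN(c2ccc(Nc3ncc4nc(Nc5ccc(F)cc5)n([C@H]5CCCN(S(=O)(=O)C6CC6)C5)c4n3)cc2)CC1` — 8.6 nM in a functional assay on HCC827 cells (Homo sapiens) for antiproliferative activity, read by MTT assay, with a stated time of 72 h; a higher number here means a weaker inhibitor, a lower number a stronger inhibitor
compound 2 `CN1CCN(c2ccc(Nc3ncc4nc(Nc5ccc(F)cc5)n(CCNS(=O)(=O)C5CC5)c4n3)cc2)CC1` — 50 nM

Compound 2 stands highest of the two numbers in this assay; compound 1 is the nearest, separated by a 5.8-fold higher number from compound 1 to compound 2 (0.76 log units; beyond the scatter). That single step went from a ring-bearing substituent to an open chain on the aromatic nitrogen.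

Compound 3 `CN1CCN(c2ccc(Nc3ncc4nc(Nc5ccc(F)cc5)n([C@@H]5CCN(C(=O)OC(C)(C)C)C5)c4n3)cc2)CC1` carries 1-(tert-butoxycarbonyl)pyrrolidin-3-yl in place of 2-((cyclopropylsulfonyl)amino)ethyl on an aromatic nitrogen. Among the measured compounds shown here, this restores a ring-bearing substituent at that nitrogen, so the one relevant step suggests a lower number, of modest size and beyond the scatter. Compound 3 is expected near 15 nM, within 5 nM to 60 nM, an estimated step of a 3.3-fold lower number from compound 2 to compound 3 (0.52 log units; beyond the scatter).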

Compound 3, half-maximal inhibitory concentration: 27 nM
Compound 3: middle estimate off by 1.8-fold (0.26 log units), on the low side; measured number inside the range.
By their numbers in this assay, from the lowest: compound 1; then compounds 3 and 2 (each within the scatter of the next).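

In this assay, a 1.9-fold lower number from compound 2 to compound 3 (0.27 log units; within the scatter), so at this aromatic nitrogen the 1-(tert-butoxycarbonyl)pyrrolidin-3-yl ring does not separate from the open 2-((cyclopropylsulfonyl)amino)ethyl chain: a ring alone does not reproduce compound 1. With a 3.1-fold higher number from compound 1 to compound 3 (0.50 log units; beyond the scatter), the 1-(cyclopropylsulfonyl)piperidin-3-yl group of compound 1 stays apart from both other groups, although ring size and the group on the ring nitrogen change together in this step. No measured evidence accounts for either step.

Still open, as far as these compounds go, is which of those two changes carries the step. A 1-(tert-butoxycarbonyl)piperidin-3-yl group, a 1-(cyclopropylsulfonyl)pyrrolidin-3-yl group or a free ring amine would bear on this.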